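The compounds below may be only part of what the source reports. "The series", "measured", "known", "first", "only" and "open" are said of these compounds alone.

Compound 1 `CC(C)n1cc(C(=O)C(=O)Nc2ccc(C(F)(F)F)nc2)c2ccccc21` and compound 2 `COc1nc(NC(=O)C(=O)c2cn(C(C)C)c3ccccc23)ns1` share the same core and differ only in the aromatic group on the amide nitrogen. In a functional assay on FaDu cells (Homo sapiens) for cytotoxicity, read by MTT assay, with a stated time of 72 h (on this read-out higher numbers stand for lower toxicity in this test and lower numbers for higher toxicity in this test), compound 1 gives > 10000 nM, which is a limit of the assay rather than a number. Compound 2 likewise gives > 10000 nM in this assay, again a limit. Compound 2 therefore stands at the limit of > 10000 nM in this assay, at which 2 of the 2 values shown sit. Compound 3 `COc1ccc(NC(=O)C(=O)c2cn(C(C)C)c3ccccc23)nn1` differs from compound 2 by a group of 8 heavy atoms (5 carbon, 2 nitrogen, 1 oxygen; one six-membered aromatic ring with 2 hetero atoms) in place of a group of 7 heavy atoms (3 carbon, 2 nitrogen, 1 oxygen, 1 sulfur; one five-membered aromatic ring with 3 hetero atoms), on an amide-type nitrogen. For the measured compounds named here, no measured step between compounds is available, so the step that the limit leaves unreadable from compound 2 to compound 3 is expected to lie within the usual scatter. Compound 3 is estimated at 15000 nM, between 5000 nM and 50000 nM.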

Compound 3, concentration lethal to 50% of the cells: 2270 nM
The estimate for compound 3 lay 6.6-fold (0.82 log units) above the measured number; measured number below the stated range.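

On this amide-type nitrogen, the aromatic group can change the result: putting 6-methoxypyridazin-3-yl in place of the five-membered ring of compound 2 gives, in this assay, an at least 4.4-fold lower number from compound 2 to compound 3 (0.64 log units; beyond the scatter). A lower number here means higher toxicity in this test, so compound 3 is the first compound shown with a toxicity that can be read as a number. The true size of the step stays unknown, since compound 2 gives only a limit: the limit of > 10000 nM in this assay, at which 2 of the 3 values shown sit.

From the compounds shown here alone, what the methoxy group contributes remains open, as does the effect of an amine in its place on the same six-membered ring.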